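A few compounds are considered here, and "the series" means these few. Any claim that something is new, unique, unknown or untested is made for them only; others in the source may bear on it.

Compound 1 `Cc1cccc(NNC(=O)c2ccc(NS(=O)(=O)c3cnc(O)nc3O)cc2)c1`: > 20000 nM
Compound 2 `O=C(NNc1ccccc1Cl)c1ccc(NS(=O)(=O)c2cnc(O)nc2O)cc1`: 3630 nM
Compound 3 `Cc1cccc(NNC(=O)c2ccccc2NS(=O)(=O)c2cnc(O)nc2O)c1`: > 20000 nM

Of the compounds shown here, three have so far been tested in a functional assay on SGC-7901 cells (Homo sapiens) for antiproliferative activity, read by MTT assay, with a stated time of 24 h; on this read-out higher numbers stand for weaker inhibition and lower numbers for stronger inhibition. For compound 1 the result is only a limit of the assay, > 20000 nM, not a number. Compound 2, in this assay, gives 3630 nM. These two differ in one place: 2-chlorophenyl in place of 3-methylphenyl on an amine nitrogen. That change produced an at least 5.5-fold lower number from compound 1 to compound 2 (0.74 log units; beyond the scatter); the size of this step is known only as a lower bound because compound 1 sits at the limit of > 20000 nM in this assay, at which 2 of the 3 values shown sit.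

Compound 3 is built from the same atoms as compound 1, joined differently; the difference between the two cores is not broken down here. For compound 3 the result is again only a limit of the assay, > 20000 nM.

Compound 4 `O=C(NNc1ccccc1Cl)c1ccccc1NS(=O)(=O)c1cnc(O)nc1O` has not yet been measured in this assay. It is related to compound 3 by 2-chlorophenyl in place of 3-methylphenyl on an amine nitrogen. For the measured compounds named here, the place is the same in both pairs, an amine nitrogen whose other neighbour is an amide-type nitrogen, so this is the same change as the one from compound 1 to compound 2. The same kind of step is expected on the core of compound 3, an at least 2.5-fold lower number from compound 3 to compound 4 (0.39 log units; beyond the scatter), resting on the measured step of an at least 5.5-fold lower number from compound 1 to compound 2 (0.74 log units; beyond the scatter); the core of compound 3 has not been tested with this change before, so the estimate is wide. Compound 4 is estimated at 8000 nM, with a likely range from 2000 nM to 30000 nM.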

Compound 4, half-maximal inhibitory concentration: > 20000 nM
Compound 4: a limit, no number (the forecaster's own chance of this, stated with the estimate: 40%); middle value at least 2.5-fold (0.39 log units) from the limit.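

In this assay compound 4 gives only a limit of the assay, > 20000 nM, not a number. Compound 3 also gives only a limit, so no step can be read between compound 3 and compound 4, because both sit at the same limit: the limit of > 20000 nM in this assay, at which 3 of the 4 values shown sit.

The compounds shown leave open whether 2-chlorophenyl in place of 3-methylphenyl on an amine nitrogen lowers the number on the core of compound 3, as it does on the core of compound 1.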